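A few compounds are considered here, and "the series" means these few. Any claim that something is new, unique, unknown or untested is made for them only; others in the source may bear on it.

Measured so far in a functional assay on MGC-803 cells (Homo sapiens) for cytotoxicity, read by MTT assay, with a stated time of 48 h; a lower number here means a stronger inhibitor, a higher number a weaker inhibitor

compound 1 `CC1=NN(C(=O)COc2ccc(Cl)cc2)C(c2cc(Br)ccc2O)C1` 23600 nM
compound 2 `CC1=NN(C(=O)COc2ccc(Cl)cc2)C(c2cc(Br)cc(Br)c2O)C1` 50000 nM
compound 3 `CC1=NN(S(=O)(=O)c2ccc(C)cc2)C(c2cc(Br)ccc2O)C1` 30700 nM

Compound 3 at 30700 nM lies within the scatter of both compound 1 and compound 2, so it cannot be clearly ordered against either, although those two are separated by more than the scatter. The unmeasured compound 4 `CC1=NN(S(=O)(=O)c2ccc(C)cc2)C(c2cc(Br)cc(Br)c2O)C1` differs from compound 3 at one place, with bromo in place of hydrogen on an aromatic carbon, ortho to a hydroxy group bromo in place of hydrogen on an aromatic carbon in the counted terms. The same replacement has been measured only once, as a 2.1-fold higher number from compound 1 to compound 2 (0.33 log units; beyond the scatter) and that step was modest. The two pairs carry different groups elsewhere on the shared core, so this single precedent is only a rough guide. A modest step toward a higher number is therefore expected in this assay as the likely outcome. The estimated change is a 1.9-fold higher number from compound 3 to compound 4 (0.28 log units; within the scatter) and it rests on that one step. Compound 4 is expected at 58000 nM with an estimated range from 28000 nM to 120000 nM as its limits.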

Compound 4, half-maximal inhibitory concentration: "not active" (no number reported)
Nothing numeric was reported for compound 4, so the estimate cannot be set against anything.
By their numbers in this assay, from the lowest: compounds 1, 3 and 2 (each within the scatter of the next, the first and the last beyond it).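

Going by these compounds alone, compound 4 is reported as "not active" in this assay with no number, so no step from compound 3 to compound 4 can be read, and no evidence bears on this result. The compounds shown leave open whether bromo in place of hydrogen has the same effect in compound 3 as in compound 1.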